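Saturated to unsaturated chain on an aromatic ether

The compounds below may be only part of what the source reports. "The series", "measured", "known", "first", "only" and "open" are said of these compounds alone.

The measured compounds and their values:
compound 1, `CC(C)=CCC/C=C(\C)Cc1c(OC/C=C(\C)CCC=C(C)C)cc(O)c2c(=O)cc(-c3ccccc3)oc12`, > 100000 nM;
compound 2, `CCCCCCCCCCCCCCCCCCOc1cc(O)cc(O)c1C(C)=O`, > 100000 nM;
compound 3, `C=C1CC[C@H]2C(C)(C)CCC[C@]2(C)[C@H]1CC/C(C)=C/COc1cc(O)c2c(=O)c(O)c(-c3ccc(O)cc3)oc2c1`, > 100000 nM.

All three were tested in a functional assay on HT-29 cells (Homo sapiens) for cytotoxicity, read by XTT assay, with a stated time of 72 h; a lower number here means a stronger inhibitor, a higher number a weaker inhibitor. Each value recorded is a limit of the assay rather than a number. Compound 1 sits at the limit of > 100000 nM. Compound 3 likewise sits at the limit of > 100000 nM. Compound 2, the starting point of the step described here, also sits at the limit of > 100000 nM. Thus compound 2 stands level with the other two on the numbers shown, none of the three having given a measurable inhibitory concentration, as the limit of > 100000 nM in this assay, at which 3 of the 3 values shown sit, records.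

The compound not yet measured is compound 4, `CCCCCCCC/C=C\CCCCCCCCOc1cc(O)cc(O)c1C(C)=O`. It differs from compound 2 in one place: dec-1-en-1-yl in place of decyl on a saturated chain carbon, eight bonds along the chain from an oxygen on an aromatic ring. Within the data shown here, no step between measured compounds is available to guide expectations for this kind of change, so the expectation rests only on where compound 2 stands.

It is expected that the step from compound 2 to compound 4 in this assay amounts to none beyond the usual scatter, that is a step that the limit leaves unreadable from compound 2 to compound 4. Compound 4 is therefore estimated at 150000 nM, within a range from 50000 nM to 500000 nM, with a high chance that the assay again reports only a limit.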

Compound 4, half-maximal inhibitory concentration: 31000 nM
The estimate for compound 4 lay 4.8-fold (0.68 log units) above the measured number; measured number outside the range, below it.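

The change yields the only measurable number among the compounds shown: in this assay, compound 4 gives 31000 nM. At this place on a saturated chain carbon, eight bonds along the chain from an oxygen on an aromatic ring, dec-1-en-1-yl in place of decyl brings an at least 3.2-fold lower number from compound 2 to compound 4 (0.50 log units; beyond the scatter), so one double bond outside aromatic rings, with the carbon count of the group unchanged, is enough to move the reading beyond the scatter. The step can be stated only as a lower bound, because compound 2 gives no number of its own: the limit of > 100000 nM in this assay, at which 3 of the 4 values shown sit.

Compound 1 and compound 3 differ from compound 2 in more than one place, so they cannot show whether the same change would have any effect on another core. Going by these compounds, it also remains open how a triple bond at this place, a double bond elsewhere along the chain, or a shorter chain would read in this assay.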